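Removing the Methoxy from the Anilide of Compound 1

This account rests on a few compounds, and the source may have more. Where it says the series, first, only, none or still open, it means among the compounds named here.

For the measured compounds named here, compound 1 `C=CC1=C(C(=O)Nc2ccccc2OC)C(c2ccc(F)cc2)OC1` is the only member of this small set to return a number in a functional assay on QGY7701 cells (Homo sapiens) for cytotoxicity, read by MTT assay, with a stated time of 24 h (a higher number here means a weaker inhibitor, a lower number a stronger inhibitor), where compound 1 gives 52800 nM. Compound 2 `C=CC1=C(C(=O)NC2CCCCC2)C(c2ccc(OC)cc2)OC1` stops at the limit of the measurement, giving > 100000 nM in this assay. Compound 3 `C=CC1=C(C(=O)Nc2ccccc2OC)C(c2ccc(OC)cc2)OC1` likewise stops at the limit, giving > 100000 nM. Moving from compound 1 to compound 3 gives an at least 1.8-fold higher number from compound 1 to compound 3 (0.27 log units; that floor lies within the scatter), while the step that the two limits leave unreadable from compound 2 to compound 3 cannot be sized because of the limit of > 100000 nM in this assay, at which 2 of the 3 values shown sit. Compound 4 `C=CC1=C(C(=O)Nc2ccccc2)C(c2ccc(F)cc2)OC1` differs from compound 1 by hydrogen in place of methoxy on an aromatic carbon. Going by the values given here, no measured step touches this part of the structure in a readable way, so for compound 4 the step is expected to stay within the scatter, as a 1.1-fold higher number from compound 1 to compound 4 (0.06 log units; within the scatter). Compound 4 is therefore expected to give 60000 nM, within 25000 nM to 150000 nM.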

Compound 4, half-maximal inhibitory concentration: 46700 nM
The estimate for compound 4 lay 1.3-fold (0.11 log units) above the measured number; the measured number falls inside the stated range.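

Going from 2-methoxyphenyl to phenyl gives a 1.1-fold lower number from compound 1 to compound 4 (0.05 log units; within the scatter), the first readable step at this place, ortho to a large group. In this assay, compound 1 and compound 4 therefore cannot be told apart, so with fluoro kept on the other aromatic ring, the methoxy group can be exchanged for hydrogen with no change beyond the scatter.

The compounds shown leave open whether an amine or a carboxylic acid at this place would separate from compound 4 in this assay. The step from compound 2 to compound 3 cannot be read, and the anilide's contribution with methoxy in place of fluoro stays open: the limit of > 100000 nM in this assay, at which 2 of the 4 values shown sit.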